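The source may hold more compounds than are shown below. What is called first, only, known or untested is meant among the compounds shown, and "the series" means these compounds.

Measured in an ADME assay on the whole organism for inhibition, with Oryza sativa as the target, with a stated time of 4 days; on this read-out lower numbers stand for stronger inhibition and higher numbers for weaker inhibition:
- compound 1 `CCCNc1nc(Cl)nc(N[C@@H](C)c2ccccc2)n1`: 32400 nM
- compound 2 `CCN(CC)c1nc(Cl)nc(N[C@H](C)c2ccccc2)n1`: 6310 nM
- compound 3 `CCCN(C)c1nc(Cl)nc(N[C@@H](C)c2ccccc2)n1`: 5500 nM

Compound 3 lies within the scatter of compound 2 and well under compound 1. The next compound, compound 4 `CCN(CC)c1nc(Cl)nc(N[C@@H](C)c2ccccc2)n1`, has diethylamino in place of methyl(propyl)amino on an aromatic carbon. Going by the values given here, the only measured step, a 5.9-fold lower number from compound 1 to compound 3 (0.77 log units; beyond the scatter), puts methyl in place of hydrogen on a nitrogen, a different change, so it bears only indirectly. Compound 2 also carries diethylamino, with the opposite configuration at its chiral carbon, and gives 6310 nM. On that value, no step beyond the scatter is expected in this assay. The expected step is a 1.3-fold higher number from compound 3 to compound 4 (0.10 log units; within the scatter). For compound 4 the estimated value is 7000 nM, with an expected range of 2500 nM to 20000 nM.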

Compound 4, half-maximal inhibitory concentration: 380 nM
Compound 4: middle estimate off by 18-fold (1.27 log units), on the high side; measured number outside the range, below it.
By their numbers in this assay, from the lowest: compound 4; then compounds 3 and 2 (each within the scatter of the next); then compound 1.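

In this assay the stereocentre at the saturated chain carbon, drawn S, gives a 17-fold lower number from compound 2 to compound 4 (1.22 log units; beyond the scatter), and nothing else changes: the fact that compounds 2 and 4 differ only in the configuration as drawn

With that configuration held, the amino group on the aromatic carbon also counts, even between two groups of the same atoms: diethylamino gives a 14-fold lower number from compound 3 to compound 4 (1.16 log units; beyond the scatter) against methyl(propyl)amino, and an 85-fold lower number from compound 1 to compound 4 (1.93 log units; beyond the scatter) against propylamino.

Going by these compounds, it remains open whether the change of amino group counts the same way with the stereocentre drawn R. It also remains open whether dipropylamino or piperidinyl at this position would keep the low number.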